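Ether side chains and cytotoxicity in a small series

The compounds below may be only part of what the source reports. "The series", "measured", "known", "first", "only" and "open" are said of these compounds alone.

Measured compounds:
Compound 1 `COc1ccc2c(c1)[n+]([O-])nc(NCOC(C)c1ccccc1)[n+]2[O-]`: > 100000 nM
Compound 2 `[O-][n+]1nc(NCOC2CCCCC2)[n+]([O-])c2ccccc21`: 6670 nM

Read-out is a functional assay on PC-3 cells (Homo sapiens) for cytotoxicity, read by MTT assay, with a stated time of 72 h; on this read-out lower numbers stand for stronger inhibition and higher numbers for weaker inhibition. The value of compound 1 is the limit of > 100000 nM in this assay, at which 1 of the 2 values shown sits, not a number. Compound 2 gives 6670 nM and is the only number shown in this assay; it stands alone, with nothing to rank it against.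

Compound 3 `CCCCCCCOCNc1n[n+]([O-])c2ccccc2[n+]1[O-]` differs from compound 2 by heptyl in place of cyclohexyl on an oxygen on a saturated carbon. Among the measured compounds shown here, no step between measured compounds is available to size this change. The expected step from compound 2 to compound 3 is a 1.2-fold higher number from compound 2 to compound 3 (0.08 log units; within the scatter), within the usual scatter. Compound 3 is therefore expected to give 8000 nM in this assay, estimated between 2500 nM and 25000 nM.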

Compound 3, half-maximal inhibitory concentration: 390 nM
The estimate for compound 3 lay 21-fold (1.31 log units) above the measured number; measured number outside the range, below it.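

In this assay this position on the ether side chain proves sensitive: heptyl in place of cyclohexyl on an oxygen on a saturated carbon gives a 17-fold lower number from compound 2 to compound 3 (1.23 log units; beyond the scatter). Loss of the ring and the gain of one carbon come together in this single change, and the pair cannot separate them. Nothing measured here bears on the cause of the step.

Open, going by these compounds, is whether a longer chain such as decyl or a shorter one such as butyl keeps this gain. Also open, on these data alone, is whether a terminal amine on the heptyl chain is tolerated.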